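The source may hold more compounds than are shown below. What is called first, only, known or untested is meant among the compounds shown, and "the series" means these compounds.

Measured so far:
compound 1 `CCCNc1nc(NCc2ccc(C(=O)Nc3ccc(F)cc3)cc2)c2cc(C)ccc2n1` — 1300 nM
compound 2 `CCCNc1nc(NCc2ccc(C(=O)Nc3ccc(F)cc3)cc2)c2ccccc2n1` — 1600 nM

Compound 1 gives the lowest of the two numbers in a functional assay on SW480 cells (Homo sapiens) for inhibition, read by luminescence and resazurin assay, with a stated time of 3 days (a higher number here means a weaker inhibitor, a lower number a stronger inhibitor), with compound 2 nearest at 1600 nM; the step of a 1.2-fold higher number from compound 1 to compound 2 (0.09 log units; within the scatter) is within the scatter, so the two are not told apart. That step concerns hydrogen in place of methyl on an aromatic carbon of the shared core and is the only one measured.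

Compound 3 `CCCNc1nc(NCc2ccc(C(=O)Nc3ccc(Cl)nc3)cc2)c2cc(C)ccc2n1` differs from compound 1 at a different place: 6-chloropyridin-3-yl in place of 4-fluorophenyl on an amide-type nitrogen. Within the data shown here, no measured step touches the group on the amide-type nitrogen, so there is nothing in the numbers to set a direction for this change. The expectation is therefore a step of no change at the digits printed from compound 1 to compound 3 (within the scatter) of no more than the scatter in either direction. Compound 3 is estimated at 1300 nM in this assay, with a range from 450 nM to 3800 nM.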

Compound 3, half-maximal inhibitory concentration: 2100 nM
Compound 3: the middle estimate sits 1.6-fold (0.21 log units) below what was measured; the range from low to high includes it.
By their numbers in this assay, from the lowest: compounds 1, 2 and 3 (each within the scatter of the next).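

The group on the amide-type nitrogen now has its first measured step: in this assay, 6-chloropyridin-3-yl in place of 4-fluorophenyl gives a 1.6-fold higher number from compound 1 to compound 3 (0.21 log units; within the scatter). The change adds a hetero atom to the six-membered aromatic ring and one hydrogen-bond acceptor by count, and exchanges fluorine for chlorine at an equal heavy-atom count, yet compound 1 and compound 3 are not told apart at this position. No measurement available here bears on the reason for this result.

Still open, as far as these compounds go, is whether a saturated ring such as cyclohexyl, or a phenyl ring carrying a carboxylic acid, on the amide-type nitrogen would give a step beyond the scatter. Also open, from the compounds shown here alone, is whether 6-chloropyridin-3-yl behaves the same way on the core of compound 2, which has hydrogen in place of methyl.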